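The source may hold more compounds than are shown below. What is called first, only, known or untested is meant among the compounds shown, and "the series" means these compounds.

Measured compounds:
Compound 1, `C=C(Br)C(=O)Nc1cccc(-c2cn3nc(-c4ccc(OCC)cc4)sc3n2)c1`: 1400 nM
Compound 2, `C=C(Br)C(=O)Nc1cccc(-c2cn3c(-c4ccccc4)csc3n2)c1`: 2800 nM

The two measured compounds share an acrylamide-bearing aniline linked to a fused bicyclic core, and differ in the group carried on that core. In a functional assay on CCRF-CEM cells (Homo sapiens) for inhibition, read by cell counting, with a stated time of 3 days (a lower number here means a stronger inhibitor, a higher number a weaker inhibitor), compound 1 gives 1400 nM, and compound 2 gives 2800 nM. The gap between these two numbers lies within the usual scatter of repeated measurements, so the data do not separate compound 1 from compound 2; compound 1 simply stands at one end of a pair whose members cannot be told apart.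

Compound 3, `C=C(Br)C(=O)Nc1cccc(-c2cn3nc(CCc4ccccc4)sc3n2)c1`, has not yet been measured. Relative to compound 1 the change is phenethyl in place of 4-ethoxyphenyl on an aromatic carbon. Within the data shown here, no measured pair follows a change of this kind, so the size of the step in this assay can only be guessed. The step from compound 1 to compound 3 is expected to be modest, a 1.8-fold higher number from compound 1 to compound 3 (0.25 log units; within the scatter), toward a somewhat higher number, though it may well fall within the scatter. Compound 3 is therefore estimated at 2500 nM, with a range from 900 nM to 7000 nM.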

Compound 3, half-maximal inhibitory concentration: 4200 nM
Compound 3: middle estimate off by 1.7-fold (0.23 log units), on the low side; the measured number falls inside the stated range.
By their numbers in this assay, from the lowest: compounds 1, 2 and 3 (each within the scatter of the next, the first and the last beyond it).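

At the aromatic carbon next to the ring nitrogen and next to the ring sulfur, phenethyl in place of 4-ethoxyphenyl gives a 3.0-fold higher number from compound 1 to compound 3 (0.48 log units; beyond the scatter) in this assay, so this position responds measurably to a change of its group, which the earlier pair, whose members could not be told apart and which differ in more than one place, could not show. Both groups carry one six-membered aromatic ring of carbon only, so the step comes with that ring kept but reached through a chain rather than attached directly, and with the ether oxygen of 4-ethoxyphenyl gone. Nothing available on the properties of these compounds bears on why the number rises, so the step stands as an observation only.

The compounds shown leave open whether the step follows the chain, the missing oxygen, or both, since the two changes travel together in this one pair. An unsubstituted phenyl at this carbon, a 4-hydroxyphenyl, or a longer chain such as 3-phenylpropyl would each pull these apart, and an amine on the ring would test how far this position tolerates a wholly different group.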